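This account rests on a few compounds, and the source may have more. Where it says the series, first, only, none or still open, it means among the compounds named here.

Three compounds have been measured:

Compound 1, `COc1ccc2c(=O)c(/C=C/C(=O)NCc3ccc(F)cc3)coc2c1`, gives 133000 nM in an ADME assay on HepG2 2.2.15 cells (Homo sapiens) for cytotoxicity, read by MTT assay, with stated times of 48 h and 9 days; on this read-out higher numbers stand for lower toxicity in this test and lower numbers for higher toxicity in this test.
Compound 2, `O=C(/C=C/c1coc2cc(O)ccc2c1=O)NCc1ccc(F)cc1`, gives 357000 nM in this assay.
Compound 3, `Cc1ccccc1NC(=O)/C=C/c1coc2cc(O)ccc2c1=O`, gives 374000 nM in this assay.

Compound 2 and compound 3 share the same oxygen-bearing core and differ only at the amide, as shown here: 2-methylphenyl in place of 4-fluorobenzyl on an amide-type nitrogen. That change made a 1.0-fold higher number from compound 2 to compound 3 (0.02 log units; within the scatter), so the two compounds sit together on this read-out. Compound 1 differs from compound 2 by a single change: methyl in place of hydrogen on an oxygen on an aromatic ring. This step was a 2.7-fold lower number from compound 2 to compound 1 (0.43 log units; beyond the scatter), the one difference among the three that stands out from the noise.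

Compound 4, `COc1ccc2c(=O)c(/C=C/C(=O)Nc3ccccc3C)coc2c1`, is the compound that carries both changes at once. Against compound 3 it differs as follows: methyl in place of hydrogen on an oxygen on an aromatic ring. The place of this change is described in the same words as that from compound 2 to compound 1, so it is the same change, set on the core that bears the 2-methylphenyl amide instead of the 4-fluorobenzyl amide.

If that change acts the way it did from compound 2 to compound 1, the step from compound 3 to compound 4 is expected to be a 2.7-fold lower number from compound 3 to compound 4 (0.43 log units; beyond the scatter), resting on compound 3 at 374000 nM. Compound 4 is therefore estimated at 140000 nM, in a range from 70000 nM to 280000 nM, in this assay.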

Compound 4, half-maximal cytotoxic concentration: 59700 nM
Compound 4: middle estimate off by 2.3-fold (0.37 log units), on the high side; measured number below the stated range.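

Hydroxy to methoxy on the 2-methylphenyl amide gave a 6.3-fold lower number from compound 3 to compound 4 (0.80 log units; beyond the scatter) in this assay, the same direction as on the 4-fluorobenzyl amide, which here means more toxicity in this test, and the two steps do not differ in size beyond what repeat measurements would allow: the same change on two cores in this assay, a 2.7-fold lower number (0.43 log units; beyond the scatter) from compound 2 to compound 1 and a 6.3-fold lower number (0.80 log units; beyond the scatter) from compound 3 to compound 4, 2.3-fold (0.37 log units) apart, within the scatter of two such steps

The amide swap, read between the two methoxy compounds, gave a 2.2-fold lower number from compound 1 to compound 4 (0.35 log units; beyond the scatter), and although the same swap between the two hydroxy compounds showed no change, these two readings cannot be told apart either: the same change on two cores in this assay, a 1.0-fold higher number (0.02 log units; within the scatter) from compound 2 to compound 3 and a 2.2-fold lower number (0.35 log units; beyond the scatter) from compound 1 to compound 4, 2.3-fold (0.37 log units) apart, within the scatter of two such steps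

So the methoxy step carried over in direction on both cores, but two pairs show neither a fixed size for it nor why it occurs, and they set no rule for other amides.

The compounds shown leave open what a longer chain on that oxygen, such as ethyl or propyl, would do to this read-out. They also leave open whether an amine or a carboxylic acid on the amide side would keep the same step.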